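The source may report more compounds than this note shows. Statements on the series, on what has been measured and on what is new or still open speak of the compounds shown alone.

In a functional assay on A549 cells (Homo sapiens) for inhibition, tested at 0.1 uM (a higher number here means a stronger effect of the compound at the concentration tested, a lower number a weaker effect), compound 2 `Cc1ccc(S(=O)(=O)n2cc(-c3cc(C(F)(F)F)ccn3)c3cc(Br)ccc32)cc1` gives 38.9%, compound 3 `Cc1ccc(S(=O)(=O)n2cc(-c3cc(C(F)(F)F)ccn3)c3cc(OCc4ccccc4)ccc32)cc1` gives 16.9%, and compound 1 `Cc1ccc(S(=O)(=O)n2cc(-c3cc(C(F)(F)F)c(C#N)c(-c4cn(S(=O)(=O)c5ccc(C)cc5)c5ccc(Br)cc45)n3)c3cc(Br)ccc32)cc1` gives 9.8%. Compound 3 thus stands second of the three, within the scatter of compound 1 and beyond the scatter below compound 2. Compound 4 `COc1ccc2c(c1)c(-c1cc(C(F)(F)F)ccn1)cn2S(=O)(=O)c1ccc(C)cc1` differs from compound 3 by hydrogen in place of phenyl on a saturated chain carbon bound to an oxygen on an aromatic ring. For the measured compounds named here, the one measured step on that aromatic carbon, a number 22 percentage points lower from compound 2 to compound 3 (beyond the scatter), concerned a different exchange, so no measured step speaks directly to the loss of the phenyl. With the bromo analogue compound 2 giving 38.9% and compound 3 giving 16.9%, the smaller methoxy is expected to land between those two. The expected step is a number 7.1 percentage points higher from compound 3 to compound 4 (within the scatter), a small one. Compound 4 is therefore estimated to give 24%, within 6% to 44%.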

Compound 4, a percentage reported as inhibition, at one concentration (the size of the read-out at that concentration, not a potency): 16.9%
Estimate against measurement, compound 4: 7.1 percentage points above; measured number inside the range.
By their numbers in this assay, from the lowest: compounds 1, 3 and 4 (each within the scatter of the next); then compound 2.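

In this assay, taking the phenyl off the benzyloxy group leaves the read-out in place (no change at the digits printed from compound 3 to compound 4 (within the scatter)), so the phenyl does not account for the gap to the bromo compound. Methoxy in place of bromo gives a step (a number 22 percentage points lower from compound 2 to compound 4 (beyond the scatter)) of the same printed size as benzyloxy in place of bromo (a number 22 percentage points lower from compound 2 to compound 3 (beyond the scatter)), so on this aromatic carbon the two oxygen-linked groups stand equally far from bromo. No measured evidence explains this result. On these data alone, whether the oxygen itself or the absence of bromo sets this gap stays open. A chloro group or an amine on the same carbon could separate the two.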